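A few compounds are considered here, and "the series" means these few. Any claim that something is new, unique, unknown or untested is made for them only; others in the source may bear on it.

Of the compounds shown here, three have been measured in a functional assay for inhibition, with Homo sapiens as the target (on this read-out lower numbers stand for stronger inhibition and higher numbers for weaker inhibition), so far. Compound 1 `COC(=O)[C@H](CC1CCCCC1)Nc1nc2ccccc2o1` gives 5 nM on this read-out while compound 2 `Fc1ccc(C(CC2CCCCC2)Nc2nc3ccccc3o2)cc1` gives 170 nM and compound 3 `CCOC(=O)c1ccc2oc(NC(CC3CCCCC3)c3ccccc3)nc2c1` gives 45 nM there. Compound 3 therefore holds the second highest of the three numbers, with both gaps beyond the scatter, lower than the number of compound 2 and higher than that of compound 1. Compound 4 `CC(=O)Nc1ccc2oc(NC(CC3CCCCC3)c3ccccc3)nc2c1` takes acetamido in place of ethoxycarbonyl on an aromatic carbon and keeps the rest of compound 3 unchanged. Within the data shown here, no two measured compounds differ in one place only, so the data hold no direct precedent for this exchange and any forecast stays uncertain. In this assay a moderate step toward a higher number, meaning weaker inhibition, is expected, although a step within the scatter cannot be ruled out. The estimated change is a 2.4-fold higher number from compound 3 to compound 4 (0.39 log units; beyond the scatter) on this reasoning. For compound 4 the estimated value is 110 nM with an expected range from 30 nM to 400 nM in this assay.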

Compound 4, half-maximal inhibitory concentration: 78 nM
Beside the measured number, compound 4's estimate is 1.4-fold (0.15 log units) above it, within the range that was stated.
By their numbers in this assay, from the lowest: compound 1; then compounds 3 and 4 (each within the scatter of the next); then compound 2.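

Among these compounds, for the first time, two compounds differ in one place only: in this assay, putting acetamido in place of ethoxycarbonyl on this aromatic carbon gives a 1.7-fold higher number from compound 3 to compound 4 (0.24 log units; within the scatter). The two compounds therefore cannot be told apart on this read-out, even though acetamido carries a hydrogen-bond donor that ethoxycarbonyl lacks, so at this position, para to a fused ring, the read-out does not separate the two groups. Nothing on hand accounts for this result.

What the compounds shown leave open is how the number would respond to a bare hydrogen, an amine or a carboxylic acid on this same carbon, and so whether any group here matters at all. They also leave open whether the same exchange would behave alike on the scaffold of compound 1, which has a methyl ester in another place.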